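A few compounds are considered here, and "the series" means these few. Any claim that something is new, unique, unknown or untested is made for them only; others in the source may bear on it.

Measured compounds in a functional assay on PC-3 cells (Homo sapiens) for cytotoxicity, read by MTT assay; on this read-out lower numbers stand for stronger inhibition and higher numbers for weaker inhibition:
- compound 1 `Cc1ccccc1Nc1nc(C)c(C(=O)/C=C/c2ccc(Cl)cc2)s1` — in this assay compound 1 gives only a limit, > 25000 nM.
- compound 2 `Cc1nc(Nc2ccc(Cl)c(Cl)c2)sc1C(=O)/C=C/c1ccccc1` — in this assay compound 2 gives 7990 nM.
- compound 3 `Cc1nc(Nc2cccc(Cl)c2)sc1C(=O)/C=C/c1ccc(Cl)cc1` — in this assay compound 3 gives only a limit, > 25000 nM.

Compound 3 thus stands at the limit of this assay, and no number is known for it. Among the compounds with values here, the one step that reaches it, a step that the two limits leave unreadable from compound 1 to compound 3, runs between two limits and its size cannot be read; the limit of > 25000 nM in this assay, at which 2 of the 3 values shown sit, is all that can be said of both ends.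

Compound 4 `Cc1nc(Nc2ccc(Cl)c(Cl)c2)sc1C(=O)/C=C/c1ccc(Cl)cc1` is not yet measured. It differs from compound 3 by chloro in place of hydrogen on an aromatic carbon. Within the data shown here, no measured step covers this change. Among the measured compounds shown here, compound 2 carries the same 3,4-dichlorophenyl as compound 4 but an unsubstituted phenyl on the other end, and its value in this assay is a number rather than a limit; as no step from compound 2 to compound 4 is among the measured ones, only that much can be taken from it.

With compound 3 at a limit, the step of an at least 1.6-fold lower number from compound 3 to compound 4 (0.22 log units; that floor lies within the scatter) is an estimate whose lower end cannot be fixed. The expected value for compound 4 in this assay is 15000 nM, with a range from 5000 nM to 40000 nM, and a real chance that compound 4 likewise returns only a limit.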

Compound 4, half-maximal inhibitory concentration: > 25000 nM
Compound 4 ended at the assay's limit (the forecaster's own chance of this, stated with the estimate: 50%); at least 1.6-fold (0.22 log units) between middle value and limit.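

With the 3,4-dichlorophenyl held fixed, chloro in place of hydrogen on the phenyl at the other end gives the first readable step of the series in this assay, an at least 3.1-fold higher number from compound 2 to compound 4 (0.49 log units; beyond the scatter), and with it the only number among these compounds gives way to a limit. The 3-chlorophenyl to 3,4-dichlorophenyl change, with the new chloro ortho to a chloro group and para to a large group, does not bring a chlorinated cinnamoyl-end compound off the limit, so this change alone does not recover a number. The steps that join two limits cannot be read, and their size stays unknown: the limit of > 25000 nM in this assay, at which 3 of the 4 values shown sit.

Going by these compounds, whether the 3-chlorophenyl or the 2-methylphenyl would also give a number with the unsubstituted phenyl at the other end remains open, so the weight of that end across different nitrogen substituents is not settled. Also open, on these data alone, is whether a methoxy group, a nitrile or a dimethylamino group in place of that chloro would keep the read-out off the limit in this assay.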